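A Methyl Group Gives Way to Hydrogen

This account rests on a few compounds, and the source may have more. Where it says the series, first, only, none or still open, it means among the compounds named here.

In a functional assay on LoVo cells (Homo sapiens) for cytotoxicity, read by MTT assay, with a stated time of 72 h (on this read-out lower numbers stand for stronger inhibition and higher numbers for weaker inhibition), compound 1 (`COc1ccc2[nH]c(-c3ccc[nH]3)cc2c1`) gives 26000 nM and compound 2 (`Cc1ccc2[nH]c(-n3cccn3)c(C3=C(Br)C(=O)NC3=O)c2c1`) gives 27000 nM as its reading, two values within the usual scatter of each other. Compound 2 therefore stands level with compound 1 on the numbers at hand. Among the measured compounds shown here, the single change leading to compound 3 (`O=C1NC(=O)C(c2c(-n3cccn3)[nH]c3ccccc23)=C1Br`) from compound 2 is hydrogen in place of methyl on an aromatic carbon and nothing else. For the measured compounds named here, no measured pair differs in one place, so the data give no direct guide to such a step in this assay and no shift beyond the scatter is expected, in either direction. The estimated change is small (a 1.1-fold lower number from compound 2 to compound 3 (0.03 log units; within the scatter)) and remains only an expectation. For compound 3 the expected value is 25000 nM with an estimated range from 9000 nM to 60000 nM until a measurement is available.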

Compound 3, half-maximal inhibitory concentration: 24000 nM
Compound 3: middle estimate off by 1.0-fold (0.02 log units), on the high side, within the range that was stated.
By their numbers in this assay, from the lowest: compounds 3, 1 and 2 (each within the scatter of the next).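

In this assay, among the compounds shown here, the exchange of methyl for hydrogen on this aromatic carbon gives a 1.1-fold lower number from compound 2 to compound 3 (0.05 log units; within the scatter), the first direct reading of a change at this position. The methyl group can therefore leave this carbon, meta to a fused ring and para to a fused ring, with no shift that this assay can distinguish from the scatter, so on these numbers the reading does not depend on it. Nothing at hand offers an explanation for why the reading holds when the methyl group is gone.

As far as these compounds go, whether an amine, a carboxylic acid or a longer chain on the same aromatic carbon would move the reading beyond the scatter remains open. This single step also cannot show whether the same exchange would behave alike on another core.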